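Swapping a Small Ring for an Aryl Ether

A few compounds are considered here, and "the series" means these few. Any claim that something is new, unique, unknown or untested is made for them only; others in the source may bear on it.

Compound 1 `Clc1cccc(-n2ncnc2NCc2cccnc2)c1Cl` gives 117 nM in a functional assay for antagonist activity at P2X purinoceptor 7 (Homo sapiens), read by FLIPR and calcium flux; a higher number here means a weaker inhibitor, a lower number a stronger inhibitor. Within the data shown here, compound 2 `Clc1cccc(-n2ncnc2NCc2cccnc2N2CCC2)c1Cl` gives 9.12 nM in this assay, the lowest of the two numbers measured so far, reached through a 13-fold lower number from compound 1 to compound 2 (1.11 log units; beyond the scatter). Compound 3 `Clc1cccc(-n2ncnc2NCc2cccnc2Oc2cccnc2)c1Cl` has not yet been measured; it differs from compound 2 by (pyridin-3-yl)oxy in place of azetidin-1-yl on an aromatic carbon. Among the measured compounds shown here, only one measured step touches this position: a 13-fold lower number from compound 1 to compound 2 (1.11 log units; beyond the scatter) shows that placing a group on this aromatic carbon moved the number strongly, but no measured pair shows what happens when one group there is exchanged for another. The outcome is therefore uncertain, and some of the gain won in compound 2 may be kept or lost. For compound 3 the expected value is 30 nM, with a range from 5 nM to 200 nM. The expected step is a 3.3-fold higher number from compound 2 to compound 3 (0.52 log units; beyond the scatter), a modest weakening that stays well inside the wide uncertainty.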

Compound 3, half-maximal inhibitory concentration: 13.8 nM
The estimate for compound 3 lay 2.2-fold (0.34 log units) above the measured number; low and high end bracket the measured number.
By their numbers in this assay, from the lowest: compounds 2 and 3 (each within the scatter of the next); then compound 1.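

Exchanging azetidin-1-yl for (pyridin-3-yl)oxy brings a 1.5-fold higher number from compound 2 to compound 3 (0.18 log units; within the scatter) in this assay, so this aromatic carbon next to the ring nitrogen accepts both a four-membered non-aromatic ring and a larger six-membered aromatic ring held through oxygen. The gain over hydrogen also survives the exchange, with an 8.5-fold lower number from compound 1 to compound 3 (0.93 log units; beyond the scatter) now standing beside the first step, and so it does not depend on azetidin-1-yl alone. Nothing available explains why these two different groups give results within the scatter of each other.

The compounds shown leave open whether the gain needs a ring at all, a question that small open-chain groups such as methoxy or dimethylamino could answer. Also open, going by these compounds, is how a carboxylic acid or a longer alkyl chain at this carbon would compare.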